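This account rests on a few compounds, and the source may have more. Where it says the series, first, only, none or still open, it means among the compounds named here.

Measured so far in an in vitro ADME assay on a cell-free system (plasma) for pharmacokinetics; a higher number here means that the compound lasts longer, a lower number that the compound disappears faster:
- compound 1 `C=CCN(CCCC(=O)O)C(=O)/C(C)=C/c1ccc(C(=O)Oc2ccc(C(=N)N)cc2)cc1`: > 1 h
- compound 2 `CCOC(=O)CCCN(C(=O)/C(C)=C/c1ccc(C(=O)Oc2ccc(C(=N)N)cc2)cc1)C(C(=O)OCC)C(=O)OCC`: < 0.0167 h

Compound 1 gives > 1 h in this assay, and this is a limit of the assay rather than a number, as the limit of > 1 h in this assay, at which 1 of the 2 values shown sits, shows. Compound 2 gives < 0.0167 h, which is likewise a limit of the assay, as the limit of < 0.0167 h in this assay, at which 1 of the 2 values shown sits, shows. For the measured compounds named here, compound 1 thus stands at the long-lived end of what the assay reports, while the two values show only that one measured compound sits at each end; the two structures differ in several places, so no single change can be read from them.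

Compound 3 `C/C(=C\c1ccc(C(=O)Oc2ccc(C(=N)N)cc2)cc1)C(=O)N(CC(=O)O)C1CCCC1` has not yet been measured. It differs from compound 1 in one place: (carboxymethyl)(cyclopentyl)amino in place of allyl(3-carboxypropyl)amino on a carbonyl carbon. Going by the values given here, no measured pair shows a change of this kind. The expected step in this assay is a step that the limit leaves unreadable from compound 1 to compound 3, that is, nothing beyond the usual scatter. Compound 3 is therefore estimated at 1.5 h, within a range from 0.5 h to 5 h.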

Compound 3, half-life: 0.383 h
Beside the measured number, compound 3's estimate is 3.9-fold (0.59 log units) above it; the measured number lies below the stated range.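

The value of compound 1, > 1 h, is a limit of the assay and not a number: the limit of > 1 h in this assay, at which 1 of the 3 values shown sits.

In this assay compound 3 gives 0.383 h, the first value shown here that is a number rather than a limit. The change on this carbonyl carbon gives an at least 2.6-fold lower number from compound 1 to compound 3 (0.41 log units; beyond the scatter), so this position matters for how long the compound lasts, even though the two groups have the same count of heavy atoms and of hydrogen-bond donors.

The two groups differ in more than one feature, so the compounds shown leave open whether the step follows from the cyclopentyl ring, the carboxymethyl chain or the loss of the allyl group. Also open, from the compounds shown here alone, is how this position would respond to a cyclohexyl ring or to an amine in place of the carboxylic acid.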